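A few compounds are considered here, and "the series" means these few. Any claim that something is new, unique, unknown or untested is made for them only; others in the source may bear on it.

Values in a functional assay for inhibition, with Homo sapiens as the target; on this read-out higher numbers stand for weaker inhibition and lower numbers for stronger inhibition:

compound 1 `CC(C)(C)Sc1c(CC(C)(C)C(=O)O)n(Cc2ccc(Cl)cc2)c2ccc(OCc3nc4ccccc4s3)cc12` gives 3 nM
compound 2 `CC(C)(C)Sc1c(CC(C)(C)C(=O)O)n(Cc2ccc(Cl)cc2)c2ccc(OCc3nc4ccccc4o3)cc12` gives < 7 nM
compound 3 `CC(C)(C)Sc1c(CC(C)(C)C(=O)O)n(Cc2ccc(Cl)cc2)c2ccc(OCc3cccc(Cl)n3)cc12` gives 3 nM

The entry for compound 2 is a limit and not a number. Compound 3 at 3 nM stands level with compound 1 at 3 nM.

The next step leads to compound 4 `C[C@H](COc1ccc2c(c1)c(SC(C)(C)C)c(CC(C)(C)C(=O)O)n2Cc1ccc(Cl)cc1)c1ccccn1`, which is not yet measured. The change is 1-(pyridin-2-yl)ethyl in place of 6-chloropyridin-2-yl on a saturated chain carbon bound to an oxygen on an aromatic ring.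

For the measured compounds named here, three measured steps bear on this place. The step of no change at the digits printed from compound 1 to compound 3 (within the scatter) lies within the scatter. The steps a step that the limit leaves unreadable from compound 1 to compound 2 and a step that the limit leaves unreadable from compound 2 to compound 3 cannot be sized. Going by the values given here, the only readable evidence is therefore one step of no visible size, and it exchanges one aromatic group for another directly on the chain carbon. Among the compounds with values here, no measured compound carries the 1-(pyridin-2-yl)ethyl group, and none tests the defined stereocentre, so the data give only a weak guide here.

Given the flat step no change at the digits printed from compound 1 to compound 3 (within the scatter), a large shift in this assay is not expected, though a modest move towards weaker inhibition is allowed for. The new group lies outside what has been measured. The expected step is a 2.0-fold higher number from compound 3 to compound 4 (0.30 log units; within the scatter). Compound 4 is estimated at 6 nM, with an expected range from 2 nM to 20 nM.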

Compound 4, half-maximal inhibitory concentration: 3 nM
The estimate for compound 4 lay 2.0-fold (0.30 log units) above the measured number, and the stated range covers the measured number.
By their numbers in this assay, from the lowest: compounds 1, 3 and 4 (each within the scatter of the next).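

In this assay, the exchange of 6-chloropyridin-2-yl for 1-(pyridin-2-yl)ethyl on the saturated chain carbon gives no change at the digits printed from compound 3 to compound 4 (within the scatter), and the exchange of 1,3-benzothiazol-2-yl for the same group gives no change at the digits printed from compound 1 to compound 4 (within the scatter). For the compounds shown here, the one readable earlier step only swapped one aromatic group for another directly on this chain carbon, whereas these steps show that the number also holds with a group that carries its pyridine ring on an ethyl chain, has no chlorine and brings a defined stereocentre. Compound 2 carries a limit and not a number, so none of its steps, including the one to compound 4, can be read: the limit of < 7 nM in this assay, at which 1 of the 4 values shown sits.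

Still open, going by these compounds, is whether the opposite configuration at the stereocentre of compound 4 gives the same number in this assay. Also open, on these data alone, is whether the number stays flat when this place carries a group with no aromatic ring at all, such as a cyclohexyl group, a primary amine or a carboxylic acid.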